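The source may report more compounds than this note shows. Statements on the series, on what has been measured and on what is new or still open speak of the compounds shown alone.

In an assay on HeLa cells for inhibition of Deoxyuridine 5'-triphosphate nucleotidohydrolase, mitochondrial (Homo sapiens), read by crystal violet staining, with a stated time of 24 h (a lower number here means that less compound is needed, a higher number that more compound is needed for the effect), compound 2 `CC(C)(NS(=O)(=O)c1cccc(OC2CCCC2)c1)c1ccc(Cn2ccc(=O)[nH]c2=O)cc1` gives 120 nM, numerically the smaller of the two figures so far, though it lies within the scatter of compound 1 `CC(C)(NS(=O)(=O)c1cccc(OCC2CC2)c1)c1ccc(Cn2ccc(=O)[nH]c2=O)cc1`, which gives 140 nM. Among the compounds with values here, the single measured step, a 1.2-fold lower number from compound 1 to compound 2 (0.07 log units; within the scatter), altered the group on the same oxygen and stayed within the scatter. Compound 3 `CC(C)(NS(=O)(=O)c1cccc(OCC(F)F)c1)c1ccc(Cn2ccc(=O)[nH]c2=O)cc1` carries 2,2-difluoroethyl in place of cyclopentyl on an oxygen on an aromatic ring. Within the data shown here, only that step bears on the new change, and it was small, so no step beyond the scatter is firmly expected in this assay, with a modestly higher number allowed for. Compound 3 is therefore estimated at 200 nM, ranging from 80 nM to 600 nM. That expectation corresponds to a 1.7-fold higher number from compound 2 to compound 3 (0.22 log units; within the scatter).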

Compound 3, half-maximal effective concentration: 100 nM
Compound 3: the middle estimate sits 2.0-fold (0.30 log units) above what was measured; measured number inside the range.
By their numbers in this assay, from the lowest: compounds 3, 2 and 1 (each within the scatter of the next).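

In this assay, swapping cyclopentyl for 2,2-difluoroethyl on this oxygen gives a 1.2-fold lower number from compound 2 to compound 3 (0.08 log units; within the scatter) and so shows that a group with no ring and with fluorine holds the number here as well as the two ring-bearing groups do. The change from cyclopropylmethyl gives a 1.4-fold lower number from compound 1 to compound 3 (0.15 log units; within the scatter) and leaves all three compounds level. Nothing available explains this tolerance. As far as these compounds go, whether an amine, a carboxylic acid or a longer chain on this oxygen would keep the number stays open.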